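From cyclohexyl to 2-cyclohexylethyl on the carbonyl carbon

The source may hold more compounds than are shown below. What is called first, only, known or untested is meant among the compounds shown, and "the series" means these compounds.

In an ADME assay on P388D1 cells (Mus musculus) for cytotoxicity, read by fluorescence and resazurin assay, with a stated time of 72 h (a higher number here means a weaker inhibitor, a lower number a stronger inhibitor), compound 1 (`O=C(Nc1ncc(Cc2cccc3ccccc23)s1)C1CCCCC1`) gives > 40000 nM as a limit of the assay, not a number. On these data alone, compound 2 (`O=C(Nc1ncc(Cc2csc3ccccc23)s1)C1CCCCC1`) stays "not determined" (no result reported) and has no number of its own, so its standing remains open. Next comes compound 3 (`O=C(CCC1CCCCC1)Nc1ncc(Cc2csc3ccccc23)s1`). The change 2-cyclohexylethyl in place of cyclohexyl on a carbonyl carbon puts 2-cyclohexylethyl in place of cyclohexyl on a carbonyl carbon. Resting on the limit of > 40000 nM in this assay, at which 1 of the 2 values shown sits, for compound 1, no step beyond the scatter is expected in this assay in either direction. For compound 3 the estimate is 30000 nM with an expected range from 10000 nM to 60000 nM and a limit of the assay in place of a number is quite possible.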

Compound 3, half-maximal inhibitory concentration: 16900 nM
For compound 3 the middle estimate is 1.8-fold (0.25 log units) above the measured one, and the stated range covers the measured number.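

No step can be read from compound 2 to compound 3: in this assay compound 2 has no number of its own, while compound 3 gives 16900 nM. On these data alone, what 2-cyclohexylethyl in place of cyclohexyl does to this read-out stays open.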